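A few compounds are considered here, and "the series" means these few. Any claim that something is new, unique, unknown or untested is made for them only; others in the source may bear on it.

Measured compounds:
compound 1, `O=[N+]([O-])c1cccc(/N=N/N2CCCC2)c1`: 80000 nM
compound 2, `FC(F)(F)c1cccc(/N=N/N2CCCC2)c1`: > 100000 nM
compound 3, `c1ccc(/N=N/N2CCCC2)cc1`: > 100000 nM

The three share one core and differ only in a single group on the aromatic ring. In an ADME assay on Vero cells (Chlorocebus sabaeus) for cytotoxicity, read by crystal violet staining (a lower number here means that less compound is tolerated, a higher number that more compound is tolerated), compound 1 gives 80000 nM. For compound 2 the result is a limit of the assay, > 100000 nM. For compound 3 the result is likewise only a limit, > 100000 nM. Compound 3 therefore stands at the limit of > 100000 nM in this assay, at which 2 of the 3 values shown sit, and has no number of its own.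

Compound 4, with structure `Clc1ccc(/N=N/N2CCCC2)cc1`, differs from compound 3 in one place: chloro in place of hydrogen on an aromatic carbon. Two measured steps also swap a group on an aromatic carbon of the shared core: an at least 1.2-fold higher number from compound 1 to compound 3 (0.09 log units; that floor lies within the scatter) and a step that the two limits leave unreadable from compound 2 to compound 3. Neither has a readable size, and an at least 1.2-fold higher number from compound 1 to compound 2 (0.09 log units; that floor lies within the scatter) adds little. No swap of a small group here has yet produced a readable change in tolerated concentration, so no step beyond the scatter is expected in this assay. Compound 4 is estimated at 100000 nM, with a range from 30000 nM to 300000 nM, most likely again only a limit. The expected step is a number no higher from compound 3 to compound 4 (the limit leaves the size open).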

Compound 4, half-maximal cytotoxic concentration: > 100000 nM
Compound 4 was reported as a limit; the forecaster's own chance of this, stated with the estimate: 60%; the middle value sits exactly at the limit.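

In this assay, compound 3 and compound 4 both give only a limit, so the step between them cannot be read: the limit of > 100000 nM in this assay, at which 3 of the 4 values shown sit.

The compounds shown leave open how much of compound 2, compound 3 or compound 4 is tolerated past that limit, and whether these three differ at all.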